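A few compounds are considered here, and "the series" means these few. Any claim that something is new, unique, unknown or untested is made for them only; others in the source may bear on it.

Of the compounds shown here, two have been measured so far in an assay on membranes from Cerebral cortex for displacement of a labelled ligand from Neuronal acetylcholine receptor; alpha4/beta2 (Rattus norvegicus), with a stated time of 5 min; on this read-out lower numbers stand for stronger inhibition and higher numbers for weaker inhibition. Compound 1, with the structure `CN1CCC[C@H]1[C@H]1COc2c(N)cccc2O1`, gives 131 nM in this assay. Compound 2, with the structure `CN1CCC[C@H]1[C@@H]1COc2c(O)cccc2O1`, gives 550 nM in this assay, the highest of the two numbers, and it sits above compound 1 by a gap that is wider than the scatter of repeated measurements, so compound 2 is the weaker of the two.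

The next compound is compound 3, with the structure `CN1CCC[C@H]1[C@H]1COc2c(O)cccc2O1`, which has not yet been measured. Compared with compound 2, (the two compounds have the same atoms and bonds and differ only in configuration as drawn: 1 of 2 stereo elements differ; a stereocentre at a saturated ring carbon is drawn R in compound 2 and S in compound 3). Nothing enters and nothing leaves; the two compounds are built from the same atoms and bonds and are distinguished only by the way one ring carbon is drawn.

Compound 1, which gives 131 nM, carries the lower number among the pair measured. A turn of one stereocentre can shift a binding number either way, and the data do not contain a measured step for such a change. The expectation is that compound 3 moves to a lower number, a step of a 3.1-fold lower number from compound 2 to compound 3 (0.49 log units; beyond the scatter) from the value of compound 2. The estimate for compound 3 in this assay is 180 nM, with a range from 45 nM to 700 nM.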

Compound 3, inhibition constant: 1700 nM
Compound 3: the middle estimate sits 9.4-fold (0.98 log units) below what was measured; measured number outside the range, above it.
By their numbers in this assay, from the lowest: compound 1; then compound 2; then compound 3.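

In this assay, turning one saturated ring carbon from R to S, with no atom gained or lost, gives a 3.1-fold higher number from compound 2 to compound 3 (0.49 log units; beyond the scatter), so with the hydroxy group in place the drawing of this one carbon clearly matters and the R form is the stronger. That shift can be assigned to this ring carbon alone because nothing else separates the pair: the fact that compounds 2 and 3 differ only in the configuration as drawn With the configuration held the same, hydroxy in place of amino on an aromatic carbon gives a 13-fold higher number from compound 1 to compound 3 (1.11 log units; beyond the scatter), a larger step than the turn of the ring carbon, which shows that the group on the aromatic carbon also shapes the number and, in this one comparison, moves it further.

Whether the amino compound would respond to the same turn of the ring carbon in the same direction and by a similar amount remains open, and the compounds shown give no step for turning the second stereocentre. Going by these compounds, it is also open what a methoxy group or a fluorine atom would do on the same aromatic carbon, in place of the amino or hydroxy group.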